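Compound 3 to compound 4: bromo for 3-bromophenyl

The source may hold more compounds than are shown below. What is called first, only, known or untested is meant among the compounds shown, and "the series" means these compounds.

In an ADME assay on HepG2 cells (Homo sapiens) for cytotoxicity, read by CellTiter-Glo and resazurin assay, with a stated time of 72 h (on this read-out lower numbers stand for an effect already at smaller amounts and higher numbers for an effect only at larger amounts of compound), compound 1 `CCOC(=O)CCCCCOc1cccc(CN(C(=O)c2ccc(-c3cccc(-c4nnc(C)o4)c3)cc2)C(C)C)c1` gives > 26000 nM as a limit. Compound 2 `CCOC(=O)CCCCCOc1cccc(CN(C(=O)c2ccc(-c3cc(OC)cc(OC)c3)cc2)C(C)C)c1` gives > 26000 nM as a limit too. Compound 3 `CCOC(=O)CCCCCOc1cccc(CN(C(=O)c2ccc(-c3cccc(Br)c3)cc2)C(C)C)c1` gives > 26000 nM and this is again a limit, so it has no number of its own. Within the data shown here, the series so far shows the limit of > 26000 nM in this assay, at which 3 of the 3 values shown sit, and nothing finer. Compound 4 `CCOC(=O)CCCCCOc1cccc(CN(C(=O)c2ccc(Br)cc2)C(C)C)c1` carries the change bromo in place of 3-bromophenyl on an aromatic carbon with bromo in place of 3-bromophenyl para to a large group. The closest changes are a step that the two limits leave unreadable from compound 1 to compound 3 and a step that the two limits leave unreadable from compound 2 to compound 3 and also a step that the two limits leave unreadable from compound 1 to compound 2 and none of them gives a size. No shift beyond the scatter can be expected in either direction, and the expected change is a step that the limit leaves unreadable from compound 3 to compound 4 on this estimate. Compound 4 is estimated at 30000 nM with an expected range from 13000 nM to 60000 nM as a working figure.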

Compound 4, half-maximal effective concentration: > 26000 nM
Compound 4 was reported as a limit; the forecaster's own chance of this, stated with the estimate: 85%; the middle value does not contradict the limit.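

Among these compounds, no step between compound 4 and compound 1, compound 2 or compound 3 can be read in this assay, as each value is only a limit: the limit of > 26000 nM in this assay, at which 4 of the 4 values shown sit.

Where any of these compounds reaches its half-maximal effect, and whether the exchanged groups shift it, remains open.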